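A Phenoxy Group in Place of Fluoro on a Weak Isomer

This account rests on a few compounds, and the source may have more. Where it says the series, first, only, none or still open, it means among the compounds named here.

Compound 1 `CN[C@@H]1CC[C@@H](c2ccc(F)cc2)c2ccccc21`: 220 nM
Compound 2 `CN[C@H]1CC[C@@H](c2ccc(F)cc2)c2ccccc21`: 4700 nM

In a functional assay on striatum for inhibition of sodium-dependent dopamine transporter (Rattus norvegicus) (a higher number here means a weaker inhibitor, a lower number a stronger inhibitor), compound 2 gives 4700 nM, the highest number of the two measured compounds; its nearest neighbour is compound 1, which in this assay gives 220 nM. Going by the values given here, the one measured step, a 21-fold higher number from compound 1 to compound 2 (1.33 log units; beyond the scatter), rests on the fact that compounds 1 and 2 differ only in the configuration as drawn and concerns configuration alone.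

Compound 3 `CN[C@H]1CC[C@@H](c2ccc(Oc3ccccc3)cc2)c2ccccc21` keeps the configuration of compound 2 and differs from it by phenoxy in place of fluoro on an aromatic carbon. Among the compounds with values here, no measured step touches a change of substituent on that aromatic ring, so the stereochemical step offers no guide to the size or direction of this one, and the expectation is correspondingly open. The step from compound 2 to compound 3 is estimated at a 1.6-fold lower number from compound 2 to compound 3 (0.19 log units; within the scatter), with no clear direction favoured. For compound 3 the expected value in this assay is 3000 nM, with a range from 400 nM to 25000 nM.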

Compound 3, half-maximal inhibitory concentration: 6800 nM
Estimate against measurement, compound 3: 2.3-fold (0.36 log units) below, within the range that was stated.
By their numbers in this assay, from the lowest: compound 1; then compounds 2 and 3 (each within the scatter of the next).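

In this assay, the exchange of fluoro for phenoxy on this aromatic carbon gives a 1.4-fold higher number from compound 2 to compound 3 (0.16 log units; within the scatter), so compound 2 and compound 3 cannot be told apart, although the entering group brings a whole six-membered aromatic ring and seven heavy atoms where a single fluorine stood. On this configuration, then, the aromatic carbon accepts a much larger group without any step beyond the scatter, a point the stereochemical pair could not address. Nothing given here bears on why the two compounds read alike.

On these data alone, whether phenoxy would read the same way on the configuration of compound 1, where the number is lower, remains open. So does the effect at this aromatic carbon of a group such as an amine, a carboxylic acid or a longer alkyl chain.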